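The compounds below may be only part of what the source reports. "The series", "measured", "known", "first", "only" and "open" are said of these compounds alone.

Compound 1 `CCC(=O)Nc1ccc(-c2nc3cc(C(F)(F)F)ccc3[nH]2)cc1` gives a limit of >= 100000 nM in an ADME assay on MT4 cells (Homo sapiens) for cytotoxicity, read by MTT assay, with a stated time of 96 h (on this read-out higher numbers stand for lower toxicity in this test and lower numbers for higher toxicity in this test), not a number.
Compound 2 `COc1ccc(-c2nc3cc(C(F)(F)F)ccc3[nH]2)cc1` gives 2000 nM in this assay.

Compound 2 carries the only number shown; the remaining value is a limit. Compound 3 `O=C(CN1CCCC1)Nc1ccc(-c2nc3cc(C(F)(F)F)ccc3[nH]2)cc1` differs from compound 2 by (((pyrrolidin-1-yl)methyl)carbonyl)amino in place of methoxy on an aromatic carbon. Going by the values given here, the single measured step, an at least 50-fold lower number from compound 1 to compound 2 (1.69 log units; beyond the scatter), runs from an amide-bearing compound sitting at the limit of >= 100000 nM in this assay, at which 1 of the 2 values shown sits, to the methoxy compound. Compound 3 again bears an amide, so the step is expected to run the other way, large and toward less toxicity in this assay. Compound 3 is estimated at 50000 nM, within 10000 nM to 200000 nM, an expected step of a 25-fold higher number from compound 2 to compound 3 (1.40 log units; beyond the scatter).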

Compound 3, half-maximal cytotoxic concentration: 18000 nM
The estimate for compound 3 lay 2.8-fold (0.44 log units) above the measured number; the measured number falls inside the stated range.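

Replacing methoxy with (((pyrrolidin-1-yl)methyl)carbonyl)amino on this aromatic carbon gives a 9.0-fold higher number from compound 2 to compound 3 (0.95 log units; beyond the scatter) in this assay and shows that a second amide also reads as less toxic than the methoxy compound. The end of the amide chain matters too: pyrrolidin-1-yl in place of methyl gives an at least 5.5-fold lower number from compound 1 to compound 3 (0.74 log units; beyond the scatter) on the chain carbon bound to the carbonyl carbon. Compound 1 gives a limit and not a number, so that step is only a bound: the limit of >= 100000 nM in this assay, at which 1 of the 3 values shown sits.

Going by these compounds, whether the ring or its nitrogen carries this step stays open, and a dimethylamine or a piperidine in place of pyrrolidin-1-yl would separate the two. The compounds shown also leave open how a carboxylic acid at the end of the chain would read.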